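The compounds below may be only part of what the source reports. "The series", "measured", "known", "first", "only" and "open" are said of these compounds alone.

In an ADME assay on HFF cells (Homo sapiens) for cytotoxicity, with a stated time of 8 days (a higher number here means that more compound is tolerated, a lower number that less compound is tolerated), compound 1 (`CC(C)CSc1nc(N)nc2c1ncn2/C=C1/CC1(CO)CO`) gives > 300000 nM as a limit of the assay. Compound 2 (`CCCCCCCCOc1nc(N)nc2c1ncn2/C=C1/CC1(CO)CO`) likewise gives > 300000 nM as a limit. Compound 3 (`CC(C)Sc1nc(N)nc2c1ncn2/C=C1/CC1(CO)CO`) gives > 300000 nM as a limit too, so it has no number of its own and stands with the two other limits shown. Compound 4 (`CCCCSc1nc(N)nc2c1ncn2/C=C1/CC1(CO)CO`) differs from it by a single change (butyl in place of isopropyl on a sulfur) with butyl in place of isopropyl on a sulfur. The closest measured comparison is a step that the two limits leave unreadable from compound 1 to compound 3 with isopropyl in place of isobutyl on a sulfur. The two other comparisons are a step that the two limits leave unreadable from compound 1 to compound 2 and a step that the two limits leave unreadable from compound 2 to compound 3 on an aromatic carbon. What all three share is the limit of > 300000 nM in this assay, at which 3 of the 3 values shown sit, and no size can be read from them. With compound 3 at > 300000 nM as a limit, no step beyond the scatter is expected in this assay in either direction. The expected change is a number no higher from compound 3 to compound 4 (the limit leaves the size open) in this estimate. Compound 4 is estimated at 300000 nM with an expected range from 150000 nM to 300000 nM and the assay is expected to report only a limit.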

Compound 4, half-maximal cytotoxic concentration: > 300000 nM
Compound 4: only a limit was reported (the forecaster's own chance of this, stated with the estimate: 85%); the middle value lies on the limit itself.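

In this assay compound 4 is reported only as a limit, like compound 1, compound 2 and compound 3, so no step among these four compounds can be read: the limit of > 300000 nM in this assay, at which 4 of the 4 values shown sit. The compounds shown leave open where the true cytotoxic concentration of each lies and whether any of them differ.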